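The source may hold more compounds than are shown below. What is called first, only, known or untested is meant among the compounds shown, and "the series" means these compounds.

Measured in a functional assay (aorta, Cricetulus griseus) with Cricetinae gen. sp. as the target; on this read-out higher numbers stand for weaker inhibition and lower numbers for stronger inhibition:
- compound 1 `CNCCN1C(=O)C(OC(C)=O)C(c2ccc(O)cc2)Sc2ccccc21`: 112000 nM
- compound 2 `CNCCN1C(=O)C(OC(C)=O)C(c2ccc(OC)cc2)Sc2ccccc21`: 3270 nM
- compound 3 `CN(C)CCN1C(=O)C(O)C(c2ccc(O)cc2)Sc2ccccc21`: 45500 nM

Compound 2 gives the lowest of these three numbers. Compound 4 `CNCCN1C(=O)C(O)C(c2ccc(OC)cc2)Sc2ccccc21` differs from it in one place: hydrogen in place of acetyl on an oxygen on a saturated carbon. For the measured compounds named here, no measured step covers this change. Going by the values given here, the only measured step, a 34-fold lower number from compound 1 to compound 2 (1.53 log units; beyond the scatter), is methyl in place of hydrogen on an oxygen on an aromatic ring, and it is large. Compound 4 keeps that methyl, so this step bears on the change only indirectly. Compound 3, at 45500 nM, carries the same hydroxy group but lacks that methyl, and it differs from compound 2 in more than one place. A moderate rise is therefore expected, with compound 4 staying between compound 2 and compound 3. The expected change is a 3.4-fold higher number from compound 2 to compound 4 (0.53 log units; beyond the scatter). For compound 4 the estimate is 11000 nM, with an expected range from 4500 nM to 30000 nM.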

Compound 4, half-maximal inhibitory concentration: 20200 nM
The estimate for compound 4 lay 1.8-fold (0.26 log units) below the measured number; measured number inside the range.
By their numbers in this assay, from the lowest: compound 2; then compound 4; then compound 3; then compound 1.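

In this assay, the change from acetoxy to hydroxy on the saturated ring carbon gives a 6.2-fold higher number from compound 2 to compound 4 (0.79 log units; beyond the scatter), so this oxygen now has a single-change reading of its own. The step is modest, whereas the one at the oxygen on the aromatic ring, a 34-fold lower number from compound 1 to compound 2 (1.53 log units; beyond the scatter), is large, so the acetyl counts for something here but the change does not cost as much as that methyl does. Nothing available explains why the number rises at this position.

As far as these compounds go, whether a methyl ether or a longer ester such as propionyl on this oxygen would hold the number near that of compound 2 stays open. From the compounds shown here alone, it is also open whether the change from acetoxy to hydroxy has the same size when the aromatic ring carries a free hydroxy, or when the side chain ends in a dimethylamino group.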